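One ring swapped on the oxygen of compound 1

The source may hold more compounds than are shown below. What is called first, only, known or untested is meant among the compounds shown, and "the series" means these compounds.

Compound 1 `CC1(C)Oc2ccc(C#N)cc2[C@@H](Oc2ccccn2)[C@]1(C)O` carries a (pyridin-2-yl)oxy group on a saturated ring carbon. In a functional assay for inhibition, with Sus scrofa as the target (a higher number here means a weaker inhibitor, a lower number a stronger inhibitor), compound 1 gives 6000 nM as its half-maximal inhibitory concentration. Compound 2 `CC1(C)Oc2ccc(C#N)cc2[C@@H](N2CCCC2=O)[C@]1(C)O` gives 4000 nM in the same measurement, so these two numbers lie within the scatter of each other and neither can be ranked above the other. In this assay compound 3 `CC1=C(N2CCCC2=O)c2cc(C#N)ccc2OC1(C)C` reaches only a limit, > 100000 nM and not a number.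

Compound 4 `Cn1nc(O[C@@H]2c3cc(C#N)ccc3OC(C)(C)[C@@]2(C)O)ccc1=O` keeps the core of compound 1 and the oxygen on it. The change is a group of 8 heavy atoms (5 carbon, 2 nitrogen, 1 oxygen; one six-membered aromatic ring with 2 hetero atoms) in place of a group of 6 heavy atoms (5 carbon, 1 nitrogen; one six-membered aromatic ring with 1 hetero atom), on an oxygen on a saturated carbon while the shared core stays the same. Within the data shown here, one measured step bears on this: the exchange of (pyridin-2-yl)oxy for 2-oxopyrrolidin-1-yl on a saturated ring carbon gave a 1.5-fold lower number from compound 1 to compound 2 (0.18 log units; within the scatter) so no step beyond the scatter is expected in this assay for this new exchange either. That guide is a loose one, since compound 4 keeps the oxygen that compound 2 lacks, and so the expected range is wide. The estimated step is a 1.7-fold lower number from compound 1 to compound 4 (0.23 log units; within the scatter) and it stays within the scatter. For compound 4 the expected value is 3500 nM with an estimated range from 500 nM to 15000 nM for the coming measurement.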

Compound 4, half-maximal inhibitory concentration: 30 nM
Compound 4: middle estimate off by 120-fold (2.07 log units), on the high side; the whole stated range lies above it.
By their numbers in this assay, from the lowest: compound 4; then compounds 2 and 1 (each within the scatter of the next). At a limit, above all of these: compound 3.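

In this assay, among these compounds, the group on the oxygen turns out to matter far more than the earlier compounds suggested: replacing pyridin-2-yl with the larger ring gives a 200-fold lower number from compound 1 to compound 4 (2.30 log units; beyond the scatter). Among the compounds shown here, the only earlier exchange at this carbon, a 1.5-fold lower number from compound 1 to compound 2 (0.18 log units; within the scatter), gave no sign of such sensitivity, so that small step did not mean that the number stays the same whatever is attached here. Compound 4 shows that, with the shared core unchanged, an exchange on this oxygen alone can produce a large step, although nothing measured here accounts for its size.

The entering group differs from pyridin-2-yl at once in its heavy atoms, its ring hetero atoms, its double bond outside the aromatic ring and its hydrogen-bond acceptors, and these compounds cannot show which of these differences goes with the lower number. From the compounds shown here alone, a phenyl or pyrimidin-2-yl ring on the same oxygen on a saturated carbon would help to separate them, and it remains open whether either would follow compound 4 or stay with compound 1.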